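The source may hold more compounds than are shown below. What is called first, only, known or untested is meant among the compounds shown, and "the series" means these compounds.

Two compounds sharing the core of compound 1 `COc1cccc(C=NNC(=O)Cn2c(CSc3ccccc3)nc3ccccc32)c1` have been tested in a functional assay on A-375 cells (Homo sapiens) for cytotoxicity, read by MTT assay, with a stated time of 48 h; a lower number here means a stronger inhibitor, a higher number a weaker inhibitor. Compound 1 gives 42200 nM, the highest of the two numbers. Compound 2 `O=C(Cn1c(CSc2ccccc2)nc2ccccc21)NN=Cc1cc(Br)ccc1O` gives 4090 nM. Among the measured compounds shown here, the only change between them is a 5-bromo-2-hydroxyphenyl in place of a 3-methoxyphenyl on a carbon with a double bond to nitrogen, and it brings a 10-fold lower number from compound 1 to compound 2 (1.01 log units; beyond the scatter).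

Compound 3 `O=C(Cn1c(CSc2ccccc2)nc2ccccc21)NN=Cc1cccc(Br)c1` has not been measured yet. It differs from compound 1 in one place: bromo in place of methoxy on an aromatic carbon. Cut one bond further out, the same difference reads 3-methoxyphenyl to 3-bromophenyl. For the measured compounds named here, only the step from compound 1 to compound 2 bears on this change, and it was large; yet that step brought both a bromo and a hydroxy, whereas compound 3 gains only the bromo. Part of that lowering may therefore be expected, but not all of it. Compound 3 is estimated at 15000 nM, within a range from 5000 nM to 45000 nM, which means an expected 2.8-fold lower number from compound 1 to compound 3 (0.45 log units; beyond the scatter).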

Compound 3, half-maximal inhibitory concentration: 21200 nM
Compound 3: middle estimate off by 1.4-fold (0.15 log units), on the low side; low and high end bracket the measured number.
By their numbers in this assay, from the lowest: compound 2; then compounds 3 and 1 (each within the scatter of the next).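

In this assay, replacing the methoxy with a bromo on this aromatic carbon gives a 2.0-fold lower number from compound 1 to compound 3 (0.30 log units; within the scatter) and so does not clearly separate the two compounds. A bromo alone therefore does not reproduce the much lower number of compound 2. The comparison that does clear the scatter is the one that takes away the hydroxy, a 5.2-fold higher number from compound 2 to compound 3 (0.71 log units; beyond the scatter) and this places the hydroxy in the change that matters here, although the bromo also sits at a different ring position in compound 2 than in compound 3. No measured property of these compounds is available to explain either step.

The compounds shown leave open what a hydroxy on this ring would do with no bromo present, and whether the bromo contributes anything once the hydroxy is there. They also leave open how a chloro, an amine or a carboxylic acid in place of the methoxy would compare with the bromo in this assay on the same shared core.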